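A few compounds are considered here, and "the series" means these few. Any claim that something is new, unique, unknown or untested is made for them only; others in the source may bear on it.

Measured in an in vitro ADME assay on microsomes from liver (Mus musculus) for pharmacokinetics, read by LC-MS, with a stated time of 10 min, tested at 1 uM; a lower number here means slower removal, a higher number faster removal of the compound:
- Compound 1 `CN1C[C@H](C(=O)Nc2ccc(F)cc2)[C@@H](c2ccc(/C=C/C(=O)Nc3ccccc3N)cc2)C1`: 34 mL/min/kg
- Compound 2 `CN1C[C@H](C(=O)Nc2ccccn2)[C@@H](c2ccc(/C=C/C(=O)Nc3ccccc3N)cc2)C1`: 40 mL/min/kg

Compound 2, at 40 mL/min/kg, cannot be told apart from compound 1 in this assay. The step between them is a 1.2-fold higher number from compound 1 to compound 2 (0.07 log units; within the scatter).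

Compound 3 `CN1C[C@H](C(=O)NC2CC2)[C@@H](c2ccc(/C=C/C(=O)Nc3ccccc3N)cc2)C1` has not yet been measured. It keeps the core of compound 2 and carries cyclopropyl in place of pyridin-2-yl on an amide-type nitrogen.

Within the data shown here, only one measured step bears on this change, at the same amide-type nitrogen: a 1.2-fold higher number from compound 1 to compound 2 (0.07 log units; within the scatter). Among the measured compounds shown here, that step exchanges one six-membered aromatic ring for another, so no measured compound shows how a non-aromatic ring behaves there. From the compounds shown here alone, the direction therefore stays open, and no step beyond the scatter is expected.

The estimated step is a 1.2-fold lower number from compound 2 to compound 3 (0.08 log units; within the scatter). For compound 3 the expected value is 33 mL/min/kg, with an estimated range of 17 mL/min/kg to 65 mL/min/kg.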

Compound 3, clearance: 7 mL/min/kg
Beside the measured number, compound 3's estimate is 4.7-fold (0.67 log units) above it, and the stated range ends above it.
By their numbers in this assay, from the lowest: compound 3; then compounds 1 and 2 (each within the scatter of the next).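

At the amide-type nitrogen, this assay now responds clearly to the group carried there: cyclopropyl in place of pyridin-2-yl gives a 5.7-fold lower number from compound 2 to compound 3 (0.76 log units; beyond the scatter) and cyclopropyl in place of 4-fluorophenyl gives a 4.9-fold lower number from compound 1 to compound 3 (0.69 log units; beyond the scatter) in the same direction. Both steps lie beyond the scatter, whereas the exchange of one six-membered aromatic ring for another had stayed within it, so this position is not indifferent to what it carries. Nothing measured here accounts for the change.

The compounds shown leave open whether the lower number belongs to cyclopropyl alone or extends to other non-aromatic groups on this nitrogen, such as cyclobutyl or an open chain like isopropyl. They also leave open whether a cyclohexyl ring bearing an amine would behave in the same way.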